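The source may hold more compounds than are shown below. What is called first, only, known or untested is meant among the compounds shown, and "the series" means these compounds.

Measured so far: compound 1 `CCOC(=O)c1c(-c2ccc([N+](=O)[O-])cc2)n(-c2ccc(C(=O)NNC(=O)CO[N+](=O)[O-])cc2)[nH]c1=O`, which gives 27.8% in a functional assay on the whole organism (strain Wistar) for inhibition, with Rattus norvegicus as the target, read by paw edema, with a stated time of 1 h, at a dose of 6 mg/kg by the oral route; on this read-out lower numbers stand for less inhibition and higher numbers for more inhibition at the one dose given (going by the name of the read-out); compound 2 `CCOC(=O)c1c(-c2ccccc2OC)n(-c2ccc(C(=O)NNC(=O)CO[N+](=O)[O-])cc2)[nH]c1=O`, which gives 31% in this assay.

For the measured compounds named here, compound 2 holds one of only two numbers, and the single measured step, a number 3.2 percentage points higher from compound 1 to compound 2 (within the scatter), lies within the scatter, so compound 2 is not set apart from compound 1. Compound 3 `CCOC(=O)c1c(-c2ccccc2O)n(-c2ccc(C(=O)NNC(=O)CO[N+](=O)[O-])cc2)[nH]c1=O` differs from compound 2 by hydrogen in place of methyl on an oxygen on an aromatic ring. Going by the values given here, no measured step touches this oxygen: the one known step, a number 3.2 percentage points higher from compound 1 to compound 2 (within the scatter), concerns the 4-nitrophenyl to 2-methoxyphenyl exchange and was small. No movement beyond the scatter in this assay is therefore expected. Compound 3 is estimated at 30%, range 20% to 40%. This amounts to an expected step of a number 1 percentage points lower from compound 2 to compound 3 (within the scatter).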

Compound 3, a percentage reported as inhibition, in the whole organism at one dose (the size of the read-out at that dose, not a potency): 27.8%
Beside the measured number, compound 3's estimate is 2.2 percentage points above it; low and high end bracket the measured number.
By their numbers in this assay, from the lowest: compounds 1, 3 and 2 (each within the scatter of the next).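

Taking the methyl off the oxygen on the aromatic ring in this assay gives a number 3.2 percentage points lower from compound 2 to compound 3 (within the scatter) and thus the first measured step at this oxygen, with methoxy and hydroxy not told apart. The exchange of 4-nitrophenyl for 2-hydroxyphenyl gives no change at the digits printed from compound 1 to compound 3 (within the scatter), so the three aryl groups so far all sit within the scatter of one another at this dose. Nothing available bears on why these numbers stay together.

Still open, from the compounds shown here alone, is whether an amine or a carboxylic acid in place of the hydroxy would move the number beyond the scatter. Going by these compounds, a longer chain on this oxygen, such as ethoxy, is equally open.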